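Phenyl to ethyl in a cytotoxicity series

The source may hold more compounds than are shown below. What is called first, only, known or untested is meant among the compounds shown, and "the series" means these compounds.

Among the measured compounds shown here, in an ADME assay on BHK cells (Mesocricetus auratus) for cytotoxicity, read by MTT assay, with a stated time of 96 h (on this read-out lower numbers stand for higher toxicity in this test and higher numbers for lower toxicity in this test), compound 3 `FC(F)(F)c1cccc(NC(=S)Nc2ccccc2)c1` reads 41000 nM, the highest number of the three measured so far. Compound 1 `FC(F)(F)c1cccc(NC(=S)Nc2ccc(I)cc2)c1` gives 9400 nM and compound 2 `FC(F)(F)c1cccc(NC(=S)Nc2ccc(Cl)cc2)c1` gives 10000 nM. The step between these two, a 1.1-fold higher number from compound 1 to compound 2 (0.03 log units; within the scatter), stays within the scatter.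

Next comes compound 4 `CCNC(=S)Nc1cccc(C(F)(F)F)c1`, with ethyl in place of phenyl on an amide-type nitrogen. For the measured compounds named here, only two measured steps bear on this change, and only indirectly: a 4.4-fold higher number from compound 1 to compound 3 (0.64 log units; beyond the scatter) and a 4.1-fold higher number from compound 2 to compound 3 (0.61 log units; beyond the scatter). Both are modest and beyond the scatter, and each concerns only the loss of a halogen. Going by the values given here, neither removes the phenyl itself, and no measured step replaces it, so any forecast is an extrapolation with wide uncertainty. On the strength of a 4.1-fold higher number from compound 2 to compound 3 (0.61 log units; beyond the scatter), a further modest rise in this assay is expected, although a step within the scatter cannot be excluded. The expected step is a 2.0-fold higher number from compound 3 to compound 4 (0.29 log units; within the scatter). The estimated value for compound 4 is 80000 nM, with an expected range of 25000 nM to 250000 nM.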

Compound 4, half-maximal cytotoxic concentration: > 100000 nM
Compound 4: only a limit was reported; the forecaster's own chance of this, stated with the estimate: 30%; middle value at least 1.2-fold (0.09 log units) from the limit.
By their numbers in this assay, from the lowest: compounds 1 and 2 (each within the scatter of the next); then compound 3. At a limit, above all of these: compound 4.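

In this assay compound 4 stands only as a limit and not as a number: the limit of > 100000 nM in this assay, at which 1 of the 4 values shown sits. Among the compounds shown here, the earlier steps touched only the halogen, whereas this is the first change to remove the phenyl itself from the amide-type nitrogen, and ethyl in its place gives an at least 2.4-fold higher number from compound 3 to compound 4 (0.38 log units; beyond the scatter), in the same direction as the loss of halogen, towards lower toxicity in this test. Against the halogenated compounds, the same position gives an at least 10-fold higher number from compound 2 to compound 4 (1.00 log units; beyond the scatter) and an at least 10-fold higher number from compound 1 to compound 4 (1.02 log units; beyond the scatter), so in these four compounds the group on this nitrogen spans a wider range than the halogen alone, and all three steps are floors, not measured sizes.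

From the compounds shown here alone, the position of compound 4 beyond the limit remains unknown, so the size of the ethyl step cannot be set against the halogen steps. Going by these compounds, whether cyclohexyl, benzyl or a longer chain such as butyl on the same nitrogen would stay at the limit or return towards compound 3 remains open, and with it whether the rise follows from losing the aromatic ring.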